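Pyrimidine series: cytotoxicity readout and the ethyl-to-methyl cut

The compounds below may be only part of what the source reports. "The series", "measured", "known", "first", "only" and "open" are said of these compounds alone.

Measured compounds:
compound 1 `CC(C)Sc1nc(O)cc(C(C)c2ccccc2)n1`: > 200000 nM (a limit of the assay, not a number)
compound 2 `CCC(C)Sc1nc(O)cc(C(C)c2ccccc2)n1`: 200000 nM
compound 3 `CCC(c1cc(O)nc(SC(C)C)n1)c1c(F)cccc1F`: 130000 nM

In a functional assay on MT4 cells (Homo sapiens) for cytotoxicity (on this read-out lower numbers stand for higher toxicity in this test and higher numbers for lower toxicity in this test), compound 1 reaches only the limit > 200000 nM. In this assay compound 2 gives 200000 nM; compound 3 gives 130000 nM, and the two sit within the scatter of each other. The difference between the core of compound 3 and the core of compound 2 is not broken down here.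

The change from compound 2 to compound 1 is hydrogen in place of methyl on a saturated chain carbon, two bonds along the chain from a sulfur. Going by these compounds, its step is a number no lower from compound 2 to compound 1 (the limit leaves the size open); the size stays open due to the limit of > 200000 nM in this assay, at which 1 of the 3 values shown sits.

Compound 4 `CC(C)Sc1nc(O)cc(C(C)c2c(F)cccc2F)n1` is not yet measured. It differs from compound 3 by hydrogen in place of methyl on a saturated chain carbon, two bonds along the chain from two aromatic carbons. Among the compounds with values here, this is the same kind of change as the one from compound 2 to compound 1, but the place differs: there the carbon is two bonds along the chain from a sulfur, here two bonds along the chain from two aromatic carbons.

The step from compound 3 to compound 4 is expected to be about a 1.5-fold higher number from compound 3 to compound 4 (0.19 log units; within the scatter), resting on the earlier step of a number no lower from compound 2 to compound 1 (the limit leaves the size open), which did not lower the number. Compound 4 is thus estimated at 200000 nM, between 100000 nM and 400000 nM, with a real chance that only a limit is reported.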

Compound 4, half-maximal cytotoxic concentration: 167000 nM
Compound 4: middle estimate off by 1.2-fold (0.08 log units), on the high side; the range from low to high includes it.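

In this assay the cut from ethyl to methyl gives a 1.3-fold higher number from compound 3 to compound 4 (0.11 log units; within the scatter), so on the core of compound 3 this change leaves the read-out within the scatter. Set beside the same change on the core of compound 2, this gives no sign of a shift on either core, but it does not show that the change carries over with the same size: the same change on two cores in this assay, a number no lower (the limit leaves the size open) from compound 2 to compound 1 and a 1.3-fold higher number (0.11 log units; within the scatter) from compound 3 to compound 4; the limit leaves it open whether they differ The earlier step cannot be read for size, so the comparison rests on one readable step and two cores, and it stays open for that reason: the limit of > 200000 nM in this assay, at which 1 of the 4 values shown sits.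

The compounds shown leave open how the read-out would respond to a longer chain, such as propyl or butyl, in place of the methyl at this saturated chain carbon. They also leave open whether the cut from ethyl to methyl would stay within the scatter on a core carrying an amine or a carboxylic acid.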